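A few compounds are considered here, and "the series" means these few. Any claim that something is new, unique, unknown or untested is made for them only; others in the source may bear on it.

Measured compounds:
Compound 1 `CC(C)OC(=O)N1CCC(Oc2ncnc3c2CCN3c2ccc(C#N)cc2F)CC1` gives 134% in a functional assay on CHO-K1 cells with Glucose-dependent insulinotropic receptor (Homo sapiens) as the target, read by a luciferase reporter, with a stated time of 5 h; on this read-out higher numbers stand for larger maximal responses and lower numbers for smaller maximal responses.
Compound 2 `CC(C)OC(=O)N1CCC(Oc2ncnc3c2CCN3c2ccc(-c3cccn3C)cc2F)CC1` gives 44% in this assay.

Compound 1 stands highest of the two numbers; its nearest neighbour is compound 2, and the step of a number 90 percentage points lower from compound 1 to compound 2 (beyond the scatter) is large and beyond the scatter, with 1-methyl-1H-pyrrol-2-yl in place of cyano on an aromatic carbon.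

Compound 3 `CC(C)OC(=O)N1CCC(Oc2ncnc3c2CCN3c2ccc([S@@+](C)[O-])c(F)c2)CC1` has not yet been measured in this assay. It differs from compound 1 as follows: a group of 10 heavy atoms (7 carbon, 1 oxygen, 1 fluorine, 1 sulfur; one six-membered aromatic ring of carbon only) in place of a group of 9 heavy atoms (7 carbon, 1 nitrogen, 1 fluorine; one six-membered aromatic ring of carbon only), on a nitrogen on an aromatic ring in a ring. Among the compounds with values here, the single measured step, a number 90 percentage points lower from compound 1 to compound 2 (beyond the scatter), bears on this change only loosely: it shows that exchanging the cyano of the 4-cyano-2-fluorophenyl lowers the maximal response sharply, but the group that entered there was a second aromatic ring, whereas the group entering in compound 3 carries a sulfur and an oxygen in place of the nitrogen and brings no further ring. A downward step is therefore expected for compound 3, probably smaller than that step. Compound 3 is estimated at 90%, within 40% to 140%, which corresponds to an expected step of a number 44 percentage points lower from compound 1 to compound 3 (beyond the scatter).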

Compound 3, largest response reached (reported as percent of maximum), in percent of the reference or control that the assay uses: 155%
Compound 3: middle estimate off by 65 percentage points, on the low side; measured number outside the range, above it.
By their numbers in this assay, from the lowest: compound 2; then compound 1; then compound 3.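

At this place, on a nitrogen on an aromatic ring in a ring, the 4-cyano-2-fluorophenyl group can be replaced without any loss of maximal response. In this assay, the group carrying sulfur and oxygen and one defined stereocentre gives a number 21 percentage points higher from compound 1 to compound 3 (beyond the scatter), a modest rise, whereas the exchange of cyano for 1-methyl-1H-pyrrol-2-yl gave a number 90 percentage points lower from compound 1 to compound 2 (beyond the scatter). The nitrile is therefore not needed for a high maximal response in this series, and losing it does not by itself bring the drop seen with compound 2, although nothing available explains why the two replacements part in direction.

Compound 3 differs from compound 1 in the whole group on that nitrogen, so the compounds shown cannot separate the contribution of the sulfur and oxygen unit from any other difference within that group, nor show what the opposite arrangement at the stereocentre would give. They also leave open whether a sulfone, with a second oxygen on the sulfur, or a small amine or a carboxylic acid in that place would hold the response at this level.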